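Cytotoxicity outlook for compound 4 before its measurement

The source may hold more compounds than are shown below. What is called first, only, known or untested is meant among the compounds shown, and "the series" means these compounds.

Measured so far:
compound 1 `CC(=O)c1ccc2[nH]c(-c3ccc(Cl)cc3)nc2c1` — > 100000 nM
compound 2 `CC(=O)c1ccc2c(c1)nc(-c1ccc(Cl)cc1)n2C1CCCCC1` — > 100000 nM
compound 3 `CC(=O)c1ccc2c(c1)nc(-c1ccc(C(F)(F)F)cc1)n2C1CCCCC1` — 33000 nM

In an ADME assay on BHK-21 cells (Mesocricetus auratus) for cytotoxicity, read by MTT assay (a higher number here means that more compound is tolerated, a lower number that less compound is tolerated), compound 1 gives > 100000 nM, which is a limit of the assay and not a number. Compound 2 gives > 100000 nM in this assay, again a limit. Compound 3 gives 33000 nM in this assay. Compound 2 thus stands at the limit of > 100000 nM in this assay, at which 2 of the 3 values shown sit, so its place among the three values is known only as a limit, not as a number. The step that the two limits leave unreadable from compound 1 to compound 2 stays unreadable. For the measured compounds named here, the only step anchored on compound 2 is an at least 3.0-fold lower number from compound 2 to compound 3 (0.48 log units; beyond the scatter), which carried the number off the limit.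

Compound 4 `CC(=O)c1ccc2c(c1)nc(-c1ccccn1)n2C1CCCCC1` differs from compound 2 in one place: pyridin-2-yl in place of 4-chlorophenyl on an aromatic carbon. Going by the values given here, no measured step exchanges this group or touches the same position, so none bears directly on the change; only an at least 3.0-fold lower number from compound 2 to compound 3 (0.48 log units; beyond the scatter) shows that an exchange on the pendant aromatic ring can move the number beyond the scatter, in the direction of less tolerance. Compound 4 is therefore expected near the limit, with the step of an at least 1.1-fold lower number from compound 2 to compound 4 (0.04 log units; that floor lies within the scatter) estimated as none beyond the scatter. The estimate for compound 4 is 90000 nM, expected between 35000 nM and 250000 nM.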

Compound 4, half-maximal cytotoxic concentration: >= 100000 nM
Compound 4 was reported as a limit; the forecaster's own chance of this, stated with the estimate: 55%; at least 1.1-fold (0.04 log units) between middle value and limit.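

In this assay compound 4 gives >= 100000 nM, which is a limit of the assay and not a number. For the compounds shown here, compound 2 gives > 100000 nM, also a limit, so no step from compound 2 to compound 4 can be read. The compounds shown leave open whether pyridin-2-yl in place of 4-chlorophenyl changes the number at all.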